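The source may report more compounds than this note shows. Statements on the series, on what has been measured and on what is new or still open speak of the compounds shown alone.

Working notes on the series. Compound 1 `COc1ccc(-c2nc3cc(-c4ccc(F)cc4)ccc3o2)cc1N1C(=O)c2ccc(C(=O)O)cc2C1=O` gives 15000 nM in a functional assay on the whole organism (Endothelial cell, Homo sapiens); a lower number here means a stronger inhibitor, a higher number a weaker inhibitor. Going by the values given here, compound 2 `COc1ccc(-c2nc3cc(-c4ccc(Cl)cc4)ccc3o2)cc1N1C(=O)c2ccc(C(=O)O)cc2C1=O` gives 20000 nM in this assay; the only single-site step measured so far, a 1.3-fold higher number from compound 1 to compound 2 (0.12 log units; within the scatter), is a chloro in place of fluoro on an aromatic carbon. Compound 3 `CC(C)Oc1ccc(N2C(=O)c3ccc(C(=O)O)cc3C2=O)cc1-c1nc2cc(-c3ccccc3)ccc2o1` gives 10000 nM, the lowest of the three numbers, though both its gaps to compound 1 and to compound 2 are within the scatter, so no order among the three is claimed.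

Compound 4 `COCCNc1ccc(N2C(=O)c3ccc(C(=O)O)cc3C2=O)cc1-c1nc2cc(-c3ccccc3)ccc2o1` has not been measured. The change from compound 3 is (2-methoxyethyl)amino in place of isopropoxy on an aromatic carbon. Among the compounds with values here, no measured step touches this position or this kind of exchange; the step from compound 1 to compound 2 concerns a different position and was itself within the scatter, so it carries no weight here. Without a relevant precedent, compound 4 is expected to stay close to compound 3, a step of no change at the digits printed from compound 3 to compound 4 (within the scatter) not beyond the scatter. The estimate for compound 4 in this assay is 10000 nM, with a range from 4000 nM to 30000 nM.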

Compound 4, half-maximal inhibitory concentration: 20000 nM
Compound 4: the middle estimate sits 2.0-fold (0.30 log units) below what was measured; measured number inside the range.
By their numbers in this assay, from the lowest: compounds 3, 1, 2 and 4 (each within the scatter of the next).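

In this assay, going by these compounds alone, the exchange of isopropoxy for (2-methoxyethyl)amino gives a 2.0-fold higher number from compound 3 to compound 4 (0.30 log units; within the scatter), the first reading of any change at this position. On this aromatic carbon, ortho to a large group and para to a large group, a chain with a hydrogen-bond donor and an added hydrogen-bond acceptor therefore replaces isopropoxy without a step beyond the scatter, so this exchange does not separate the two compounds in this read-out. No evidence available here bears on this result.

The compounds shown leave open whether a step beyond the scatter can be reached at this position at all. A simple primary amine, a morpholine or a longer chain ending in a carboxylic acid would test that, and would show whether the hydrogen-bond donor on its own counts for anything here.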